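A Methyl on the Benzyl Ring of Compound 3

A few compounds are considered here, and "the series" means these few. Any claim that something is new, unique, unknown or untested is made for them only; others in the source may bear on it.

Measured compounds:
compound 1, `CN1CCN(CC(=O)Nc2ccc(-c3nc(-c4ccccc4)c(-c4ccccc4)n3C)cc2)CC1`: 50.3%
compound 2, `CN(C)/C=C/N1CCN(CC(=O)Nc2ccc(-c3nc(-c4ccccc4)c(-c4ccccc4)n3C)cc2)CC1`: 34.7%
compound 3, `Cn1c(-c2ccc(NC(=O)CN3CCN(Cc4ccccc4)CC3)cc2)nc(-c2ccccc2)c1-c1ccccc1`: 49.5%

All three share one core and differ only in the group on the amine nitrogen of the ring at the end of the chain. In a functional assay on MCF7 cells (Homo sapiens) for cytotoxicity, read by MTT assay, with a stated time of 24 h, tested at 80 ug/mL (a lower number here means a weaker effect, a higher number a stronger effect of the compound at the concentration tested), compound 3 stands second highest of the three numbers. Its nearest neighbour is compound 1, and the step of a number 0.8 percentage points lower from compound 1 to compound 3 (within the scatter) lies within the scatter, so the two are not told apart. The furthest is compound 2, and the step of a number 14.8 percentage points higher from compound 2 to compound 3 (beyond the scatter) is modest but beyond the scatter.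

Compound 4, `Cc1ccc(CN2CCN(CC(=O)Nc3ccc(-c4nc(-c5ccccc5)c(-c5ccccc5)n4C)cc3)CC2)cc1`, differs from compound 3 by methyl in place of hydrogen on an aromatic carbon; cut one bond further out, the change reads phenyl to 4-methylphenyl. Within the data shown here, no measured step touches the aromatic ring of the benzyl group. Among the measured compounds shown here, the only step that bears on this region is the exchange of methyl for benzyl on the ring nitrogen, a number 0.8 percentage points lower from compound 1 to compound 3 (within the scatter), which stayed within the scatter; a small addition further out on that benzyl is therefore expected to give a step of a number 0.5 percentage points lower from compound 3 to compound 4 (within the scatter), none beyond the scatter. Compound 4 is expected to give 49%, estimated between 36% and 60%.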

Compound 4, a percentage reported as activity, at one concentration (the size of the read-out at that concentration, not a potency): 49.3%
Compound 4: the middle estimate sits 0.3 percentage points below what was measured, within the range that was stated.
By their numbers in this assay, from the lowest: compound 2; then compounds 4, 3 and 1 (each within the scatter of the next).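

In this assay, among these compounds, the step of a number 0.2 percentage points lower from compound 3 to compound 4 (within the scatter) is the first reading from the aromatic ring of the benzyl group, and it does not tell 4-methylbenzyl from benzyl at this position. The step of a number 1 percentage points lower from compound 1 to compound 4 (within the scatter) also lies within the scatter, while the step of a number 14.6 percentage points higher from compound 2 to compound 4 (beyond the scatter) lies beyond it, so among the four compounds only compound 2 stands apart. Nothing at hand explains why the para methyl leaves the number in place.

Going by these compounds, whether a carboxylic acid, an amine or a methoxy group on this ring would also leave the number in place remains open, as does the effect of a methyl on another carbon of the ring. Each number comes from one concentration and says nothing about potency.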